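Pyrimidin-5-yl for Pyridin-2-yl: Expected Cytotoxicity Read-out

The source may hold more compounds than are shown below. What is called first, only, known or untested is meant among the compounds shown, and "the series" means these compounds.

In an ADME assay on BV-2 cells (Mus musculus) for cytotoxicity, with a stated time of 24 h, tested at 50 uM (a higher number here means a weaker effect of the compound at the concentration tested, a lower number a stronger effect), the three measured compounds stand as follows:
Compound 1, `COc1ccccc1S(=O)(=O)/C=C/c1ccccn1`, gives 100%.
Compound 2, `COc1ccccc1S(=O)(=O)/C=C/c1ccc(Cl)cn1`, gives 92.6%.
Compound 3, `COc1ccccc1S(=O)(=O)/C=C/c1ncccc1F`, gives 99.2%.

Compound 1 sits at the top of these three numbers, though neither gap reaches beyond the scatter: a number 0.8 percentage points lower from compound 1 to compound 3 (within the scatter) and a number 7.4 percentage points lower from compound 1 to compound 2 (within the scatter). Compound 4, `COc1ccccc1S(=O)(=O)/C=C/c1cncnc1`, differs from compound 1 by pyrimidin-5-yl in place of pyridin-2-yl on a double-bonded chain carbon bound to a double-bonded chain carbon. Both measured steps put a halogen onto the pyridin-2-yl ring and left the ring itself in place; neither moved the number beyond the scatter. Among the compounds with values here, no measured step exchanges the ring, so the change to compound 4 has no direct counterpart among the three compounds. On what is shown, with every change at this end of the molecule leaving the read-out essentially unchanged, no step beyond the scatter is expected in this assay for compound 4. Compound 4 is therefore estimated at 97%, within 85% to 100%, which would mean an expected step of a number 3 percentage points lower from compound 1 to compound 4 (within the scatter).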

Compound 4, a percentage reported as activity, at one concentration (the size of the read-out at that concentration, not a potency): 97.9%
Compound 4: middle estimate off by 0.9 percentage points, on the low side; low and high end bracket the measured number.
By their numbers in this assay, from the lowest: compounds 2, 4, 3 and 1 (each within the scatter of the next).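

In this assay the exchange of the ring itself, pyrimidin-5-yl in place of pyridin-2-yl, gives a number 2.1 percentage points lower from compound 1 to compound 4 (within the scatter) and thus no step beyond the scatter. Compound 2 and compound 3 carried a halogen on a retained pyridin-2-yl ring, whereas compound 4 shows that the ring at this place can also be replaced by one with 2 hetero atoms and 2 hydrogen-bond acceptors without a step beyond the scatter. No supporting measurement is available to explain this result.

From the compounds shown here alone, all four compounds carry a six-membered aromatic ring here, and none of their steps lies beyond the scatter, so it remains open which change at this place, if any, would move the read-out. Whether an amine, a carboxylic acid or a longer chain in place of the ring would do so is not answered by the compounds shown.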